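Dropping One Methoxy Group: What the Data Suggest

The compounds below may be only part of what the source reports. "The series", "measured", "known", "first", "only" and "open" are said of these compounds alone.

Measured compounds:
compound 1 `COc1cc(OC)c(OC)cc1/C=C/COC(=O)/C=C/c1ccc(OC)c(OC)c1`, giving 100%
compound 2 `COc1cc(OC)c(OC)cc1/C=C/COC(=O)/C=C/c1ccc(OC)c(OC)c1OC`, giving 100%

In a functional assay on the whole organism (strain Kunming) with Mus musculus as the target, with a stated time of 0.5 h, at a dose of 100 mg/kg by the intraperitoneal route (a higher number here means a weaker effect of the compound at the dose given, a lower number a stronger effect), compound 1 gives 100%, and it stands level with compound 2 at the digits shown, so neither can be called stronger or weaker. Among the measured compounds shown here, the single measured step, no change at the digits printed from compound 1 to compound 2 (within the scatter), adds a methoxy group on an aromatic carbon and leaves the read-out unchanged within the scatter.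

Compound 3 `COc1cccc(/C=C/C(=O)OC/C=C/c2cc(OC)c(OC)cc2OC)c1` differs from compound 1 in one place: hydrogen in place of methoxy on an aromatic carbon. This is a removal rather than an addition, and at a different aromatic carbon, so the measured step bears on it only loosely; it does show that one methoxy group more or less on an aromatic ring did not shift the read-out here. On that basis compound 3 is expected to show no change beyond the scatter, with the expected step being a number 5 percentage points lower from compound 1 to compound 3 (within the scatter). The estimate for compound 3 is 95%, within a range from 70% to 100%.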

Compound 3, a percentage reported as activity, at one dose (the size of the read-out at that dose, not a potency): 100%
Compound 3: middle estimate off by 5 percentage points, on the low side; the range from low to high includes it.
By their numbers in this assay, from the lowest: compounds 1, 2 and 3 (each within the scatter of the next).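

Changing the 3,4-dimethoxyphenyl to a 3-methoxyphenyl in this assay gives no change at the digits printed from compound 1 to compound 3 (within the scatter). Compound 2 covered only the gain of a methoxy group on this ring, whereas compound 3 covers a loss, at a place ortho to a methoxy group and para to a large group, and the read-out still does not move. Nothing measured here explains why this methoxy group can go without a visible change in the read-out.

The compounds shown cover only methoxy and hydrogen at this place, so it remains open whether an amine, a carboxylic acid or a longer chain such as butoxy would give a different read-out. Because compounds 1, 2 and 3 all read level, they also leave open which part of the shared core, if any, governs the read-out.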